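Adding a Trifluoromethyl Group on Two Related Cores

A few compounds are considered here, and "the series" means these few. Any claim that something is new, unique, unknown or untested is made for them only; others in the source may bear on it.

Compound 1 `CC(O)(CSc1cccc(C(F)(F)F)c1)C(=O)Nc1cccc(S(F)(F)(F)(F)F)c1` and compound 2 `CC(O)(CSc1cc(C(F)(F)F)cc(C(F)(F)F)c1)C(=O)Nc1cccc(S(F)(F)(F)(F)F)c1` share one core, while compound 3 `CC(O)(COc1ccc(C#N)cc1)C(=O)Nc1ccc(S(F)(F)(F)(F)F)cc1` is built on another; the difference between the two cores is not broken down here. In a functional assay on DU-145 cells (Homo sapiens) for antiproliferative activity, read by propidium iodide staining, with a stated time of 96 h (on this read-out lower numbers stand for stronger inhibition and higher numbers for weaker inhibition), compound 1 gives 19100 nM and compound 2 gives 9400 nM. Compound 2 differs from compound 1 in a single place: trifluoromethyl in place of hydrogen on an aromatic carbon. This change produced a 2.0-fold lower number from compound 1 to compound 2 (0.31 log units; beyond the scatter). Compound 3 gives 32200 nM in this assay. Compound 4 `CC(O)(COc1ccc(C#N)cc1C(F)(F)F)C(=O)Nc1ccc(S(F)(F)(F)(F)F)cc1` has not yet been measured; it differs from compound 3 by the same kind of change, (trifluoromethyl in place of hydrogen on an aromatic carbon). The surroundings are not identical: in compound 2 the new group sits meta to a large group and meta to a trifluoromethyl group, whereas in compound 4 it sits ortho to a large group and meta to a cyano group. Among the compounds with values here, only one measured example of this change exists, and it lies on a different core, so any expectation rests on it alone. The expected step is a 2.0-fold lower number from compound 3 to compound 4 (0.30 log units; within the scatter), leaning on the earlier step of a 2.0-fold lower number from compound 1 to compound 2 (0.31 log units; beyond the scatter). Compound 4 is therefore estimated to give 16000 nM, within a range from 7000 nM to 40000 nM.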

Compound 4, half-maximal inhibitory concentration: 21200 nM
Estimate against measurement, compound 4: 1.3-fold (0.12 log units) below; measured number inside the range.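

On the core of compound 3, trifluoromethyl in place of hydrogen on an aromatic carbon gives a 1.5-fold lower number from compound 3 to compound 4 (0.18 log units; within the scatter) in this assay, so on this core the step cannot be told apart from the ordinary spread of repeated measurements. Set beside the earlier step on the other core, its size does not differ in any way these data can detect: the same change on two cores in this assay, a 2.0-fold lower number (0.31 log units; beyond the scatter) from compound 1 to compound 2 and a 1.5-fold lower number (0.18 log units; within the scatter) from compound 3 to compound 4, 1.3-fold (0.13 log units) apart, within the scatter of two such steps. This means the two cores give no sign of treating the change differently, but it does not show that the change reliably lowers the number on the core of compound 3, and two pairs cannot establish a rule for the series, particularly as the new group stands ortho to a large group and meta to a cyano group only in compound 4.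

From the compounds shown here alone, whether a chlorine atom or an amine on that same aromatic carbon would give a step of similar size remains open. So does the effect of putting a carboxylic acid in place of the cyano group of compound 3.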